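This account rests on a few compounds, and the source may have more. Where it says the series, first, only, none or still open, it means among the compounds named here.

Measured compounds:
- compound 1, `O=C(NO)c1ccc(CN(Cc2ccc(F)cc2)c2ncc(C(=O)NCCCn3ccnc3)s2)cc1`: 14 nM
- compound 2, `O=C(CCCCCCN(Cc1ccc(F)cc1)c1ncc(C(=O)NCc2cccnc2)s1)NO`: 470 nM
- compound 3, `CC(C)CCN(CCCCCCC(=O)NO)c1ncc(C(=O)NCCCn2ccnc2)s1`: 15 nM

All three were tested in an assay on isolated protein for inhibition of Nicotinamide phosphoribosyltransferase (Homo sapiens), read by fluorescence, with stated times of 5 min and 15 min; on this read-out higher numbers stand for weaker inhibition and lower numbers for stronger inhibition. Compound 1 gives the lowest number of the three. Its nearest neighbour is compound 3, whose value sits within the usual scatter of compound 1, so the two cannot be told apart. Within the data shown here, compound 2 gives a number far above that of compound 1, a gap beyond the scatter, but the two differ in several places at once, so the values alone say only that compound 2 is the weaker inhibitor.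

The next compound, compound 4, `O=C(CCCCCN(Cc1ccc(F)cc1)c1ncc(C(=O)NCCCn2ccnc2)s1)NO`, has not yet been measured. It differs from compound 1 in one place: 4-(hydroxycarbamoyl)butyl in place of 4-(hydroxycarbamoyl)phenyl on a saturated chain carbon bound to a nitrogen on an aromatic ring. The ring of compound 1 is thus replaced by an open chain of similar reach, with the hydroxamic acid kept at the end. A chain-borne hydroxamic acid on this core can match compound 1, as compound 3 shows, giving 15 nM.

On that basis, compound 4 is expected to stay close to compound 1, with a step of a 1.8-fold higher number from compound 1 to compound 4 (0.25 log units; within the scatter) that need not exceed the scatter. The estimated value for compound 4 is 25 nM, within a range from 8 nM to 80 nM.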

Compound 4, half-maximal inhibitory concentration: 7 nM
Estimate against measurement, compound 4: 3.6-fold (0.55 log units) above; measured number outside the range, below it.
By their numbers in this assay, from the lowest: compounds 4, 1 and 3 (each within the scatter of the next, the first and the last beyond it); then compound 2.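

In this assay, putting 4-(hydroxycarbamoyl)butyl in place of 4-(hydroxycarbamoyl)phenyl on a saturated chain carbon bound to a nitrogen on an aromatic ring gives a 2.0-fold lower number from compound 1 to compound 4 (0.30 log units; within the scatter), so the two compounds cannot be told apart. Among these compounds, this is the first comparison here that changes one place only, and it shows that on this core, with everything else held the same, the six-membered aromatic ring in this group can give way to an open chain with no measurable loss of inhibition. Nothing measured explains why the two groups perform alike in this assay, and no supporting evidence bears on the result.

The compounds shown do not tell whether a shorter chain, such as 3-(hydroxycarbamoyl)propyl, or a longer one, such as 6-(hydroxycarbamoyl)hexyl, would hold up at this position on the same core. They also leave open how a carboxylic acid or an amine at the end of the chain, in place of the hydroxycarbamoyl group, would compare with compound 4.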